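This account rests on a few compounds, and the source may have more. Where it says the series, first, only, none or still open, it means among the compounds named here.

Compound 1 `N#Cc1ccc(Nc2ncc(Cc3c(F)cccc3F)o2)cc1` gives 8000 nM in an ADME assay on MT2 cells (Homo sapiens) for inhibition; a higher number here means that more compound is tolerated, a lower number that less compound is tolerated. Compound 2 `Cc1cc(F)c(Cc2cnc(Nc3ccc(C#N)c(Cl)c3)o2)c(F)c1` gives 31000 nM. Compound 3 `CCc1cc(F)c(Cc2cnc(Nc3ccc(C#N)c(Cl)c3)o2)c(F)c1` gives 10000 nM.

Of these three numbers, compound 3 holds the second highest; compound 1 lies within the scatter of it, while the step of a 3.1-fold lower number from compound 2 to compound 3 (0.49 log units; beyond the scatter) lies beyond the scatter. Compound 4 `CCC(C)c1cc(F)c(Cc2cnc(Nc3ccc(C#N)c(Cl)c3)o2)c(F)c1` differs from compound 3 by ethyl in place of hydrogen on a saturated chain carbon bound to an aromatic carbon and a saturated chain carbon; the same difference, cut one bond further out, reads ethyl to sec-butyl. Within the data shown here, the only measured step that bears on this is a 3.1-fold lower number from compound 2 to compound 3 (0.49 log units; beyond the scatter), a modest lowering when hydrogen gave way to methyl at this place. A further lengthening of the chain is therefore expected to lower the number again, by a similar modest amount. Compound 4 is thus estimated at 4500 nM (range 1800 nM to 12000 nM), which means an expected step of a 2.2-fold lower number from compound 3 to compound 4 (0.35 log units; beyond the scatter).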

Compound 4, half-maximal cytotoxic concentration: 40000 nM
The estimate for compound 4 lay 8.9-fold (0.95 log units) below the measured number; measured number outside the range, above it.
By their numbers in this assay, from the lowest: compounds 1 and 3 (each within the scatter of the next); then compounds 2 and 4 (each within the scatter of the next).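

Going from ethyl to sec-butyl reverses the direction of the earlier step: in this assay there is a 4.0-fold higher number from compound 3 to compound 4 (0.60 log units; beyond the scatter), against a 3.1-fold lower number from compound 2 to compound 3 (0.49 log units; beyond the scatter), so the number does not fall steadily as this group grows. Methyl and sec-butyl stand level, with a 1.3-fold higher number from compound 2 to compound 4 (0.11 log units; within the scatter), and ethyl gives the lowest number of the three. Nothing available accounts for this turn.

The compounds shown leave open whether branching or chain length matters, which a straight butyl chain would separate. They also leave open how an amine at this place would read.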